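This account rests on a few compounds, and the source may have more. Where it says the series, first, only, none or still open, it means among the compounds named here.

Measured so far in an ADME assay on 184B5 cells (Homo sapiens) for cytotoxicity, read by MTT assay, with a stated time of 72 h; on this read-out lower numbers stand for stronger inhibition of growth and higher numbers for weaker inhibition of growth:
compound 1 `CCOC(=O)Nc1ccc([Se]C#N)cc1`: 18600 nM
compound 2 `O=C(Nc1ccc([Se][Se]c2ccc(NC(=O)OCc3ccccc3)cc2)cc1)OCc1ccccc1`: 5800 nM
compound 3 `Cc1ccc(OC(=O)Nc2ccc([Se][Se]c3ccc(NC(=O)Oc4ccc(C)cc4)cc3)cc2)cc1`: 7600 nM

Compound 1 stands highest of the three numbers, that is, it is the weakest grower-inhibitor in this set. Compound 3 is the nearest to it, with a lower number by a gap that lies beyond the scatter; compound 2 is the furthest, with the lowest number of the three, also beyond the scatter. For the measured compounds named here, no pair among the measured compounds differs in a single place, so no step within the measured set can be read off, and the gaps between compound 1 and the other two say nothing about any one structural change.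

The next compound is compound 4 `CCCCOC(=O)Nc1ccc([Se]C#N)cc1`, which differs from compound 1 in one place: ethyl in place of hydrogen on a saturated chain carbon, two bonds along the chain from an oxygen next to a carbonyl group. Nothing in the measured set tracks this kind of change, and what enters carries no ring and no hydrogen-bond donors or acceptors. The step of a 1.2-fold lower number from compound 1 to compound 4 (0.09 log units; within the scatter) is therefore expected to be small, with no clear direction and most likely none beyond the scatter. Compound 4 is estimated at 15000 nM, within a range from 6000 nM to 40000 nM.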

Compound 4, concentration for total growth inhibition: 14500 nM
Compound 4: the middle estimate sits 1.0-fold (0.01 log units) above what was measured; the range from low to high includes it.
By their numbers in this assay, from the lowest: compounds 2, 3, 4 and 1 (each within the scatter of the next, the first and the last beyond it).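

For the compounds shown here, compound 4 gives the first comparison that differs in one place. In this assay, ethoxy to butoxy, which is ethyl in place of hydrogen on a saturated chain carbon, two bonds along the chain from an oxygen next to a carbonyl group, comes with a 1.3-fold lower number from compound 1 to compound 4 (0.11 log units; within the scatter), so on the core of compound 1 this position takes the added ethyl with no change in the read-out beyond the scatter, a finding that holds for this one pair and this one change only. No separate measurement bears on this result.

From the compounds shown here alone, it remains open whether the position stays as insensitive to a longer chain such as hexyl, or to a chain ending in an amine or a carboxylic acid, since a single ethyl step fixes no trend in either direction. Compound 2 and compound 3 differ from compound 1 and compound 4 in more than one place, so steps to them cannot be read, and the effect of the same change on their cores is also unknown.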